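Methyl for chloro on the phenoxy ring of compound 2

A few compounds are considered here, and "the series" means these few. Any claim that something is new, unique, unknown or untested is made for them only; others in the source may bear on it.

Compound 2 `Clc1ccc(OCc2ccccc2-c2nc(-c3cccc(Br)c3)cs2)cc1` stands lowest of the two numbers in hand. In a functional assay on the whole organism (strain Wistar albino) for inhibition, with Rattus norvegicus as the target, read by paw edema, at a dose of 10 mg/kg by the oral route (a lower number here means less inhibition, a higher number more inhibition at the dose given (going by the name of the read-out)), compound 2 gives 42.9%. In this assay, among the measured compounds shown here, compound 1 `Cc1ccc(OCc2ccccc2-c2nc(COc3ccc(Cl)cc3)cs2)cc1` gives 68.7%, a number beyond the scatter above that of compound 2; the two structures differ in more than one place, so no single step separates them.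

Compound 3 `Cc1ccc(OCc2ccccc2-c2nc(-c3cccc(Br)c3)cs2)cc1` differs from compound 2 by methyl in place of chloro on an aromatic carbon. For the measured compounds named here, no measured pair shows this change alone. The expected step in this assay is small, upward or none beyond the scatter, amounting to a number 7.1 percentage points higher from compound 2 to compound 3 (within the scatter). For compound 3 in this assay the estimate is 50%, within 35% to 65%.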

Compound 3, a percentage reported as inhibition, in the whole organism at one dose (the size of the read-out at that dose, not a potency): 44.5%
Compound 3: middle estimate off by 5.5 percentage points, on the high side, and the stated range covers the measured number.
By their numbers in this assay, from the lowest: compounds 2 and 3 (each within the scatter of the next); then compound 1.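

In this assay, methyl in place of chloro on the aromatic carbon para to a large group gives a number 1.6 percentage points higher from compound 2 to compound 3 (within the scatter), so this change does not separate the two groups at this position. The new compound also gives a one-place step at the other substituent of the shared core: 3-bromophenyl in place of (4-chlorophenoxy)methyl gives a number 24.2 percentage points lower from compound 1 to compound 3 (beyond the scatter), so the gap between compounds 1 and 2 is more likely tied to that substituent than to the phenoxy ring. No measurement on hand accounts for either step.

Open, going by these compounds, is how a methoxy group or an amine would read on the phenoxy ring. Also open, on these data alone, is whether a carboxylic acid or a longer chain at the other substituent would hold the level of compound 1.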